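Working notes: from compound 3 to compound 4

The compounds below may be only part of what the source reports. "The series", "measured", "known", "first", "only" and "open" are said of these compounds alone.

Compound 1 `Clc1cccc(-c2cc(-c3ccoc3)cc(-c3ccc(Cl)s3)n2)c1`: 22100 nM
Compound 2 `Cc1ccsc1-c1cc(-c2ccc(Cl)o2)cc(-c2cccc(Cl)c2)n1`: 13400 nM
Compound 3 `Cc1ccc(-c2cc(-c3ccc(Cl)o3)cc(-c3ccc(Cl)s3)n2)cc1`: 21400 nM

All three values come from a functional assay on K562 cells (Homo sapiens) for cytotoxicity, read by ELISA, with a stated time of 4 days; on this read-out higher numbers stand for weaker inhibition and lower numbers for stronger inhibition. There, compound 3, at 21400 nM, lies within the scatter of both other compounds, which also lie within the scatter of each other. Compound 4 `Clc1cccc(-c2cc(-c3ccc(Cl)o3)cc(-c3ccc(Cl)s3)n2)c1` has 3-chlorophenyl in place of 4-methylphenyl on an aromatic carbon. Among the compounds with values here, no measured pair isolates this change. Compound 2, at 13400 nM, and compound 1, at 22100 nM, also carry 3-chlorophenyl, and neither departs from compound 3 beyond the scatter. The expected 1.2-fold lower number from compound 3 to compound 4 (0.08 log units; within the scatter) is therefore small and within the scatter, with no firm direction. The estimate for compound 4 is 18000 nM, with an expected range of 8000 nM to 40000 nM.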

Compound 4, half-maximal inhibitory concentration: 19600 nM
Beside the measured number, compound 4's estimate is 1.1-fold (0.04 log units) below it, within the range that was stated.
By their numbers in this assay, from the lowest: compounds 2, 4, 3 and 1 (each within the scatter of the next).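

In this assay the three one-place steps are a 1.1-fold lower number from compound 3 to compound 4 (0.04 log units; within the scatter) with 3-chlorophenyl in place of 4-methylphenyl next to the ring nitrogen, a 1.5-fold higher number from compound 2 to compound 4 (0.17 log units; within the scatter) with 5-chlorothiophen-2-yl in place of 3-methylthiophen-2-yl, and a 1.1-fold lower number from compound 1 to compound 4 (0.05 log units; within the scatter) with 5-chlorofuran-2-yl in place of furan-3-yl. None of these aromatic swaps separates its pair beyond the scatter, so the direction of each remains unresolved. As far as these compounds go, whether an amine or a carboxylic acid on the phenyl ring would move the number beyond the scatter remains open. No supporting data bear on this flat result.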